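Hydrazinyl urea series: varying the substituent at the aromatic carbon

The source may hold more compounds than are shown below. What is called first, only, known or untested is meant among the compounds shown, and "the series" means these compounds.

Measured compounds in an assay on isolated protein for binding affinity to sphingosine 1-phosphate receptor 2 (Homo sapiens), read by surface plasmon resonance; on this read-out lower numbers stand for tighter binding and higher numbers for weaker binding:
compound 1 `COc1ccc(-c2cc(NNC(=O)Nc3cc(Cl)nc(Cl)c3)nc3c2c(C)nn3C)cc1` gives 1020 nM
compound 2 `Cc1nn(C)c2nc(NNC(=O)Nc3cc(Cl)nc(Cl)c3)cc(-c3ccco3)c12` gives 6520 nM
compound 3 `Cc1nn(C)c2nc(NNC(=O)Nc3cc(Cl)nc(Cl)c3)cc(C3CCCCC3)c12` gives 2010 nM

Compound 3 stands second highest of the three numbers in this assay; its nearest neighbour is compound 1, with a 2.0-fold higher number from compound 1 to compound 3 (0.29 log units; within the scatter) separating them, and its furthest is compound 2, with a 3.2-fold lower number from compound 2 to compound 3 (0.51 log units; beyond the scatter) separating them.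

Compound 4 `Cc1cc(NNC(=O)Nc2cc(Cl)nc(Cl)c2)nc2c1c(C)nn2C` is not yet measured. It differs from compound 3 in one place: methyl in place of cyclohexyl on an aromatic carbon. The change thus removes the six-membered non-aromatic ring and leaves a single carbon at that aromatic carbon.

For the measured compounds named here, two measured steps bear on this position. The step of a 2.0-fold higher number from compound 1 to compound 3 (0.29 log units; within the scatter) shows that exchanging 4-methoxyphenyl for cyclohexyl stays within the scatter. The step of a 6.4-fold higher number from compound 1 to compound 2 (0.81 log units; beyond the scatter) shows that furan-2-yl gives a modest loss. Neither step reaches a group as small as methyl, so the direction for compound 4 is uncertain; the shared core tolerates changes here with modest effect, and a small loss or none beyond the scatter is expected. Compound 4 is therefore estimated at 3500 nM, with a range from 1200 nM to 10000 nM. The expected step of a 1.7-fold higher number from compound 3 to compound 4 (0.24 log units; within the scatter) is a modest weakening.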

Compound 4, dissociation constant: 11000 nM
Compound 4: the middle estimate sits 3.1-fold (0.50 log units) below what was measured; the measured number lies above the stated range.
By their numbers in this assay, from the lowest: compounds 1 and 3 (each within the scatter of the next); then compounds 2 and 4 (each within the scatter of the next).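

In this assay, for the compounds shown here, methyl at this aromatic carbon gives the only step at this position graded large (an 11-fold higher number from compound 1 to compound 4 (1.03 log units; beyond the scatter)), so the position is less tolerant than the three larger groups had suggested. Replacing cyclohexyl with methyl also costs binding (a 5.5-fold higher number from compound 3 to compound 4 (0.74 log units; beyond the scatter)), although both groups have no hydrogen-bond donors or acceptors and no net charge, so these counts do not separate the two compounds. A ring at this position does not by itself keep the number low: compound 2, with furan-2-yl, goes against that pattern, since furan-2-yl and methyl lie within the scatter of each other (a 1.7-fold higher number from compound 2 to compound 4 (0.23 log units; within the scatter)), and no measurement here accounts for these differences.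

The compounds shown leave open how binding changes between methyl and cyclohexyl, which ethyl, isopropyl or cyclopropyl at the same carbon could help to define. They also leave open whether unsubstituted phenyl, a pyridine ring or a morpholine ring would match or improve on the 4-methoxyphenyl of compound 1, or whether the 4-methoxy group itself contributes to its lower number.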